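Swapping a methyl for a carbamoyl on the aromatic ring

The source may hold more compounds than are shown below. What is called first, only, known or untested is meant among the compounds shown, and "the series" means these compounds.

Measured compounds:
compound 1 `C=CC[C@H]1C[C@]2([C@@H](C)Cc3ccc(OC)cc3)OCOC2=CC1=O` gives 90 nM
compound 2 `C=CC[C@H]1C[C@]2([C@@H](C)Cc3ccc(OC)c(C)c3)OCOC2=CC1=O` gives 630 nM

For the measured compounds named here, in a functional assay on NCI-H460 cells (Homo sapiens) for antiproliferative activity, with a stated time of 72 h (a higher number here means a weaker inhibitor, a lower number a stronger inhibitor), compound 2 gives the higher of the two numbers recorded; its only neighbour is compound 1, and the step from one to the other, a 7.0-fold higher number from compound 1 to compound 2 (0.85 log units; beyond the scatter), came from methyl in place of hydrogen on an aromatic carbon. Compound 3 `C=CC[C@H]1C[C@]2([C@@H](C)Cc3ccc(OC)c(C(N)=O)c3)OCOC2=CC1=O` changes the same position again: carbamoyl in place of methyl on an aromatic carbon. Going by the values given here, no measured step swaps one substituent for another at this position, so the only guidance is that adding a group there weakened compound 2 against compound 1. A larger group is therefore expected to give a step in this assay of about a 1.7-fold higher number from compound 2 to compound 3 (0.24 log units; within the scatter), toward a higher number, though the uncertainty is wide. Compound 3 is expected to give around 1100 nM, within the range 250 nM to 5000 nM.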

Compound 3, half-maximal inhibitory concentration: 66 nM
The estimate for compound 3 lay 17-fold (1.22 log units) above the measured number; measured number below the stated range.
By their numbers in this assay, from the lowest: compounds 3 and 1 (each within the scatter of the next); then compound 2.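

The penalty seen with methyl at this position does not apply to every added group. In this assay, carbamoyl in place of methyl gives a 9.5-fold lower number from compound 2 to compound 3 (0.98 log units; beyond the scatter), and carbamoyl in place of hydrogen gives a 1.4-fold lower number from compound 1 to compound 3 (0.13 log units; within the scatter), so this larger group leaves the activity level with that of the core carrying only hydrogen there, and size alone does not set the outcome at this position. Nothing available here explains why these two groups behave so differently.

Two groups are too few to show which feature of the carbamoyl matters. A nitrile, a carboxylic acid or an amine at this position could begin to separate these possibilities, as could a methyl group on the amide nitrogen.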